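Adding one amino group to a compound with only a limit

The source may report more compounds than this note shows. Statements on the series, on what has been measured and on what is new or still open speak of the compounds shown alone.

compound 1 `COc1cc(-c2nccn2Cc2ccccc2)cc(OC)c1OC` gives "not determined" (no result reported) in the test below
compound 2 `COc1ccc(-n2ccnc2-c2cc(OC)c(OC)c(OC)c2)cc1[N+](=O)[O-]` gives "not determined" (no result reported) in the test below
compound 3 `COc1ccc(-n2ccnc2-c2cc(OC)c(OC)c(OC)c2)cc1` gives > 50000 nM in the test below, a limit

In an ADME assay on HUVEC cells (Homo sapiens) for cytotoxicity, read by MTT assay, with a stated time of 72 h (on this read-out higher numbers stand for weaker inhibition and lower numbers for stronger inhibition), compound 3 stands at > 50000 nM as a limit of the assay, not as a number. Within the data shown here, compound 1 and compound 2 have no result, so no measured step is available as a guide.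

Compound 4 (`COc1ccc(-n2ccnc2-c2cc(OC)c(OC)c(OC)c2)cc1N`) differs from compound 3 by one change (amino in place of hydrogen on an aromatic carbon): amino in place of hydrogen on an aromatic carbon, ortho to a methoxy group.

The expected step of an at least 50-fold lower number from compound 3 to compound 4 (1.69 log units; beyond the scatter) in this assay is large and towards stronger inhibition, though this is very uncertain. The estimate for compound 4 is 1000 nM within an expected range from 30 nM to 40000 nM on the same read-out.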

Compound 4, half-maximal inhibitory concentration: 58500 nM
Compound 4: middle estimate off by 59-fold (1.77 log units), on the low side; measured number above the stated range.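

No step can be read from compound 3 to compound 4, as compound 3 carries only a limit of the assay, not a number: the limit of > 50000 nM in this assay, at which 1 of the 4 values shown sits. The compounds shown leave open whether amino in place of hydrogen on an aromatic carbon changes the result at all.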